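Swapping methoxy for fluoro on a weakly cytotoxic indole pair

The source may hold more compounds than are shown below. What is called first, only, known or untested is meant among the compounds shown, and "the series" means these compounds.

Measured compounds:
Compound 1 `COc1ccc(Cn2cc(/C=C(\C#N)C(=O)c3c[nH]c4cc(OC)ccc34)c3ccccc32)cc1`: in a functional assay on PC-3 cells (Homo sapiens) for cytotoxicity, read by WST assay, with a stated time of 48 h (on this read-out lower numbers stand for stronger inhibition and higher numbers for weaker inhibition), compound 1 reaches only the assay limit, > 50000 nM.
Compound 2 `COc1ccc2[nH]cc(/C=C(\C#N)C(=O)c3c[nH]c4ccccc34)c2c1`: in this assay compound 2 gives 30500 nM.
Compound 3 `COc1ccc2c(/C=C(\C#N)C(=O)c3c[nH]c4cc(OC)ccc34)c[nH]c2c1`: in this assay compound 3 gives 27000 nM.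

All three share one core: two indole rings joined through an acrylonitrile-ketone linker. Compound 3 and compound 2 give numbers that lie within the usual scatter of each other, so they cannot be told apart on this read-out, and both remain weak. Compound 1, which carries a benzyl group on one indole nitrogen, gives no number at all, only a limit (the limit of > 50000 nM in this assay, at which 1 of the 3 values shown sits).

Compound 4 `COc1ccc2c(C(=O)/C(C#N)=C/c3c[nH]c4cc(F)ccc34)c[nH]c2c1` differs from compound 3 in one place: fluoro in place of methoxy on an aromatic carbon. Among the measured compounds shown here, no comparable change has been measured here, so there is no directly measured step to lean on. Given how close compound 2 and compound 3 sit, a change of similar scale on the other indole seems unlikely to move the number beyond the scatter. Compound 4 is therefore expected to give about 30000 nM in this assay, somewhere between 10000 nM and 90000 nM, which means an expected step of a 1.1-fold higher number from compound 3 to compound 4 (0.05 log units; within the scatter).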

Compound 4, half-maximal inhibitory concentration: 22500 nM
Beside the measured number, compound 4's estimate is 1.3-fold (0.12 log units) above it; low and high end bracket the measured number.
By their numbers in this assay, from the lowest: compounds 4, 3 and 2 (each within the scatter of the next). At a limit, above all of these: compound 1.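

Replacing methoxy with fluoro on this aromatic carbon gives a 1.2-fold lower number from compound 3 to compound 4 (0.08 log units; within the scatter) in this assay and this is the first one-place change that can be read among these compounds. It shows that methoxy is not needed at this position to hold the number at this level, while fluoro there does not lift the compound out of the weak range. Nothing measured here bears on why the two groups give such similar numbers.

Still open, from the compounds shown here alone, is whether an amine, a carboxylic acid or a longer chain at this same position would move the number beyond the scatter. Also open, going by these compounds, is whether fluoro in place of methoxy would give a similarly small step at other positions on the shared core.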